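A Thiophene Ring Replaces Ethyl on the Shared Core

The compounds below may be only part of what the source reports. "The series", "measured", "known", "first", "only" and "open" are said of these compounds alone.

Compound 1 `CCOC(=O)c1cnc(NN2C(=O)C=C(C)C2=O)nc1CC`: 400 nM
Compound 2 `CCOC(=O)c1cnc(N(C)N2C(=O)C=C(C)C2=O)nc1CC`: 35 nM

In a functional assay on Jurkat cells (Homo sapiens) for inhibition (on this read-out lower numbers stand for stronger inhibition and higher numbers for weaker inhibition), compound 2 gives 35 nM, the lowest of the two numbers, while compound 1 gives 400 nM. Among the measured compounds shown here, the only measured step, an 11-fold lower number from compound 1 to compound 2 (1.06 log units; beyond the scatter), concerns the methyl on the nitrogen and says nothing about the position changed next. Compound 3 `CCOC(=O)c1cnc(N(C)N2C(=O)C=C(C)C2=O)nc1-c1ccc(C)s1` keeps that methyl and differs from compound 2 by 5-methylthiophen-2-yl in place of ethyl on an aromatic carbon. For the measured compounds named here, no measured step bears on this change, so no direction can be drawn from the data. The expected step, a 1.1-fold higher number from compound 2 to compound 3 (0.06 log units; within the scatter), is therefore small and uncertain. The estimate for compound 3 is 40 nM, with a range from 8 nM to 250 nM.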

Compound 3, half-maximal inhibitory concentration: 350 nM
Compound 3: middle estimate off by 8.8-fold (0.94 log units), on the low side; the whole stated range lies below it.
By their numbers in this assay, from the lowest: compound 2; then compounds 3 and 1 (each within the scatter of the next).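

In this assay, 5-methylthiophen-2-yl in place of ethyl gives a 10-fold higher number from compound 2 to compound 3 (1.00 log units; beyond the scatter), so this position on the shared core clearly responds to what sits on it, and the change weakens inhibition. Compound 3 keeps the methyl on the nitrogen, so that methyl does not prevent this weakening. Nothing available explains the result. The compounds shown leave open whether a longer chain such as propyl, or a phenyl ring, would behave more like ethyl or like 5-methylthiophen-2-yl here.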